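The source may report more compounds than this note shows. Statements on the series, on what has been measured and on what is new or still open speak of the compounds shown alone.

Three compounds of the series have numbers in a functional assay on SN12C cells (Homo sapiens) for inhibition, read by sulforhodamine B assay, with a stated time of 48 h, tested at 10 uM; a lower number here means a stronger effect, a higher number a weaker effect of the compound at the concentration tested. Compound 1 `COc1cc(Cl)cc(-c2nn(-c3cccc(NC(=O)c4ccc(Cl)c(Cl)c4)c3)cc2-c2ccncc2)c1` gives 69.6%. Compound 2 `O=C(Nc1cccc(-n2cc(-c3ccncc3)c(-c3cc(O)cc(Cl)c3)n2)c1)Nc1ccc(Cl)c(C(F)(F)F)c1` gives 34.6%. Compound 3 `O=C(Nc1cccc(-n2cc(-c3ccncc3)c(-c3cc(O)cc(Cl)c3)n2)c1)Nc1ccc(Cl)c(Cl)c1` gives 14.9%. Compound 2 stands second highest of the three: compound 3 lies below it and compound 1 above it, both gaps beyond the scatter. Among the compounds with values here, the only step between compounds differing in one place is a number 19.7 percentage points lower from compound 2 to compound 3 (beyond the scatter), chloro in place of trifluoromethyl on an aromatic carbon.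

Compound 4 `COc1cc(Cl)cc(-c2nn(-c3cccc(NC(=O)Nc4ccc(Cl)c(C(F)(F)F)c4)c3)cc2-c2ccncc2)c1` is not yet measured. It differs from compound 2 by methyl in place of hydrogen on an oxygen on an aromatic ring. Within the data shown here, no measured step touches the hydroxy or methoxy group alone; the step from compound 2 to compound 3 alters a different aromatic carbon and does not bear on this change. Among the measured compounds shown here, compound 1 carries the methoxy group but differs from compound 2 in more than one place, so its number cannot be tied to that group; it shows only that the methoxy-bearing member is the highest of the three. The step in this assay is therefore expected to be small, most likely a modest rise, a number 10.4 percentage points higher from compound 2 to compound 4 (beyond the scatter). For compound 4 the estimate is 45%, within 25% to 70%.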

Compound 4, a percentage reported as activity, at one concentration (the size of the read-out at that concentration, not a potency): 13.8%
Beside the measured number, compound 4's estimate is 31.2 percentage points above it, outside the stated range (below it).
By their numbers in this assay, from the lowest: compounds 4 and 3 (each within the scatter of the next); then compound 2; then compound 1.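

Notes on the series: in this assay, hydroxy to methoxy on the 3-chloro-5-hydroxyphenyl group is the first change read at this oxygen on its own, and it gives a number 20.8 percentage points lower from compound 2 to compound 4 (beyond the scatter), so methyl in place of hydrogen here is tolerated and goes with a stronger effect in this pair. With the methoxy group held constant, (4-chloro-3-(trifluoromethyl)phenyl)amino in place of 3,4-dichlorophenyl on the carbonyl carbon gives a number 55.8 percentage points lower from compound 1 to compound 4 (beyond the scatter). No measurement shown here explains either step.

From the compounds shown here alone, whether hydroxy to methoxy gives a similar step on the 3,4-dichlorophenyl partner of compound 3 remains open. Also open, going by these compounds, is how a longer chain on this oxygen, such as ethyl, or an amine in place of the methoxy group would read.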